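Working notes: chloro in place of fluoro

A few compounds are considered here, and "the series" means these few. Any claim that something is new, unique, unknown or untested is made for them only; others in the source may bear on it.

In a functional assay on the whole organism (strain Kunming) with Mus musculus as the target, with a stated time of 0.5 h (on this read-out lower numbers stand for an effect already at smaller amounts and higher numbers for an effect only at larger amounts of compound), compound 3 `COc1cc(OC)c(OC)cc1/C=C/COC(=O)/C=C/c1ccc(F)cc1` gives 449 umol/kg. Compound 1 `COc1ccccc1/C=C/C(=O)OC/C=C/c1cc(OC)c(OC)cc1OC` gives 625 umol/kg, and these two numbers lie within the scatter of each other. Compound 2 `COc1cc(OC)c(OC)cc1/C=C/COC(=O)/C=C/c1ccccc1C(F)(F)F` reaches a limit of the assay, > 473 umol/kg, and not a number. The steps that touch compound 2 are a step that the limit leaves unreadable from compound 1 to compound 2 and an at least 1.0-fold lower number from compound 2 to compound 3 (0.02 log units; that floor lies within the scatter), so neither offers a usable size. Compound 3 therefore shares its place with compound 1, and compound 2 cannot be placed firmly against either.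

Compound 4 `COc1cc(OC)c(OC)cc1/C=C/COC(=O)/C=C/c1ccc(Cl)cc1` differs from compound 3 by chloro in place of fluoro on an aromatic carbon. This is chloro in place of fluoro on an aromatic carbon, para to a large group. For the measured compounds named here, no measured step covers this exchange itself. The closest guide is the replacement of the whole substituted phenyl group, seen as a 1.4-fold lower number from compound 1 to compound 3 (0.14 log units; within the scatter), which stays within the scatter. On that single readable step, no change beyond the scatter is expected in this assay, in either direction. The estimated step is a 1.0-fold lower number from compound 3 to compound 4 (0.02 log units; within the scatter). For compound 4 the expected value is 430 umol/kg, with an estimated range of 230 umol/kg to 800 umol/kg.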

Compound 4, dose for half-maximal effect: 364 umol/kg
Estimate against measurement, compound 4: 1.2-fold (0.07 log units) above; the range from low to high includes it.
By their numbers in this assay, from the lowest: compounds 4, 3 and 1 (each within the scatter of the next).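

Chloro in place of fluoro on an aromatic carbon, para to a large group, is now read directly in this assay: a 1.2-fold lower number from compound 3 to compound 4 (0.09 log units; within the scatter), so this exchange of one halogen for the other does not separate the two compounds on this read-out. The wider exchanges of the whole substituted phenyl group read the same way, with a 1.7-fold lower number from compound 1 to compound 4 (0.23 log units; within the scatter) and, as a floor only, an at least 1.2-fold lower number from compound 2 to compound 4 (0.11 log units; that floor lies within the scatter), so 4-chlorophenyl joins 4-fluorophenyl and 2-methoxyphenyl in one group within the scatter, with no order among them. The value of compound 2 remains a limit and not a number, and it gives this series no firm place for the 2-(trifluoromethyl)phenyl compound: the limit of > 473 umol/kg in this assay, at which 1 of the 4 values shown sits.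

Still open, as far as these compounds go, is whether any group at this position moves the read-out beyond the scatter, for instance an amine or a carboxylic acid in place of the halogen. How a longer chain in the link shared by all the compounds shown would read also remains open.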